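Adding a Methoxy Group: Compound 1 to Compound 3

A few compounds are considered here, and "the series" means these few. Any claim that something is new, unique, unknown or untested is made for them only; others in the source may bear on it.

Two measured compounds share one core and differ at a single aromatic carbon. Compound 1 `COc1ccc(C(=O)/C=C/c2cc(-c3cc(OC)c(OC)c(OC)c3)n[nH]2)cc1OC` was tested in a functional assay on HOP-62 cells (Homo sapiens) for cytotoxicity, read by sulforhodamine B assay, with a stated time of 48 h, tested at 1 uM (on this read-out lower numbers stand for a stronger effect and higher numbers for a weaker effect at the one concentration tested), where compound 1 gives 77%. Compound 2 `COc1ccc(C(=O)/C=C/c2cc(-c3cc(OC)c(OC)c(OC)c3)n[nH]2)cc1` has hydrogen in place of methoxy on an aromatic carbon; in this assay compound 2 gives 87%. The step of a number 10 percentage points higher from compound 1 to compound 2 (within the scatter) lies within the scatter. Compound 1 thus shows the lower of the two numbers, yet its distance to compound 2 is no larger than repeated measurements would give, so no order between the two can be claimed.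

Compound 3 `COc1cc(C(=O)/C=C/c2cc(-c3cc(OC)c(OC)c(OC)c3)n[nH]2)cc(OC)c1OC` has not yet been measured. It differs from compound 1 by methoxy in place of hydrogen on an aromatic carbon. Within the data shown here, the only measured step bearing on this change runs the opposite way, hydrogen in place of methoxy, and gave a number 10 percentage points higher from compound 1 to compound 2 (within the scatter), within the scatter. A small move in this assay, if any, is therefore expected, estimated as a number 7 percentage points lower from compound 1 to compound 3 (within the scatter), without passing beyond the scatter. Compound 3 is expected to give 70%, with a range from 52% to 88%.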

Compound 3, a percentage reported as activity, at one concentration (the size of the read-out at that concentration, not a potency): 78%
Estimate against measurement, compound 3: 8 percentage points below; the measured number falls inside the stated range.
By their numbers in this assay, from the lowest: compounds 1, 3 and 2 (each within the scatter of the next).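

Adding a methoxy group on the aromatic carbon that is ortho to a methoxy group and meta to a large group gave, in this assay, a number 1 percentage points higher from compound 1 to compound 3 (within the scatter), so this ring now has a measured addition of methoxy, where the earlier pair showed only a removal. Read together with a number 10 percentage points higher from compound 1 to compound 2 (within the scatter), this shows that neither taking a methoxy group away from this ring nor adding one here moved the number beyond the scatter, and neither step supports an order of compounds. No evidence available here speaks to what lies behind this result.

On these data alone, whether a different group on this aromatic carbon, such as a hydroxyl group, an amine, a carboxylic acid or a longer chain like ethoxy, would carry the number beyond the scatter stays open. As far as these compounds go, it also stays open whether these compounds would separate at another concentration, since this assay gives the size of the read-out at a single concentration and not a potency.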